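A Bromophenyl Group Replaces the Sulfonyloxy Substituent

The source may report more compounds than this note shows. Statements on the series, on what has been measured and on what is new or still open speak of the compounds shown alone.

Compound 1 `C=C[C@@](C)(/C=C/c1ccc(OS(=O)(=O)C(F)(F)F)cc1)CCC=C(C)C` is examined in a functional assay on HepG2 cells (Homo sapiens) for cytotoxicity, with a stated time of 72 h; a lower number here means that less compound is needed, a higher number that more compound is needed for the effect. In that test compound 1 reaches only the assay limit of > 52000 nM. Compound 2 `C=C[C@@](C)(/C=C/c1ccc(OS(=O)(=O)c2ccc(C)cc2)cc1)CCC=C(C)C` likewise shows only the limit > 52000 nM in this assay. Compound 3 `C=C[C@@](C)(/C=C/c1ccc(O)c(/C=C/C(=O)O)c1)CCC=C(C)C` also stops at the limit > 52000 nM. Among the compounds with values here, the single step among them, a step that the two limits leave unreadable from compound 1 to compound 2, cannot be read because of the limit of > 52000 nM in this assay, at which 3 of the 3 values shown sit. Compound 4 `C=C[C@@](C)(/C=C/c1ccc(-c2cccc(Br)c2)cc1)CCC=C(C)C` differs from compound 1 by 3-bromophenyl in place of ((trifluoromethyl)sulfonyl)oxy on an aromatic carbon. Within the data shown here, no measured step bears on this change, as every value shown is a limit, so the expected step that the limit leaves unreadable from compound 1 to compound 4 rests on nothing beyond those limits. Compound 4 is therefore expected to give about 60000 nM, between 15000 nM and 250000 nM, most probably again only as a limit.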

Compound 4, half-maximal effective concentration: > 52000 nM
Compound 4: only a limit was reported; the forecaster's own chance of this, stated with the estimate: 70%; the middle value does not contradict the limit.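

Compound 4 also stops at a limit in this assay and the step from compound 1 to compound 4 cannot be read: the limit of > 52000 nM in this assay, at which 4 of the 4 values shown sit. The compounds shown leave open which change to the shared core, if any, would yield a measurable value in this assay.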